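The source may hold more compounds than are shown below. What is called first, only, known or untested is meant among the compounds shown, and "the series" means these compounds.

Working notes on the series. Compound 1 `COc1ccc(-c2cn(C(=O)Nc3cc(OC)c(OC)c(OC)c3)c(=O)n2-c2cc(OC)c(OC)c(OC)c2)cc1` gives > 50000 nM in a functional assay on Bel-7402 cells (Homo sapiens) for cytotoxicity, read by MTT assay, with a stated time of 48 h (on this read-out higher numbers stand for weaker inhibition and lower numbers for stronger inhibition), which is a limit of the assay and not a number. Compound 2 `COc1cc(-n2c(-c3ccccc3)cn(C(C)=O)c2=O)cc(OC)c1OC` gives > 50000 nM in this assay, again only a limit. Both values shown sit there: the limit of > 50000 nM in this assay, at which 2 of the 2 values shown sit. Compound 2 therefore has no measured potency to serve as a baseline, only this limit.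

Compound 3 `COc1cc(-n2c(-c3ccc(Br)cc3)cn(C(C)=O)c2=O)cc(OC)c1OC` carries bromo in place of hydrogen on an aromatic carbon, para to a large group, so phenyl becomes 4-bromophenyl: bromo in place of hydrogen on an aromatic carbon.

Going by the values given here, no step between measured compounds exists to size this change. A small move toward stronger inhibition in this assay is expected, and a reading that stays at the limit is quite possible. The estimated step is an at least 1.2-fold lower number from compound 2 to compound 3 (0.09 log units; that floor lies within the scatter). Compound 3 is expected at 40000 nM, with an estimated range from 6000 nM to 50000 nM.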

Compound 3, half-maximal inhibitory concentration: 1200 nM
Estimate against measurement, compound 3: 33-fold (1.52 log units) above; measured number outside the range, below it.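

The change from phenyl to 4-bromophenyl gives an at least 41-fold lower number from compound 2 to compound 3 (1.61 log units; beyond the scatter), which shows that this place on the aromatic ring can move the read-out in this assay. That step is only a floor and not a true size, because its starting point is a limit of the assay and not a number: the limit of > 50000 nM in this assay, at which 2 of the 3 values shown sit. Compound 3 is the only compound shown with a measured number, so this single bromo atom is what separates a measurable compound from one at the limit within this pair.

Going by these compounds, whether this response is specific to bromo stays open, since chloro, an amine or a carboxylic acid in the same place would be needed to tell. On these data alone, whether bromo in another place on this ring would give a similar step also stays open.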